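A few compounds are considered here, and "the series" means these few. Any claim that something is new, unique, unknown or untested is made for them only; others in the source may bear on it.

In an ADME assay on microsomes from liver (Homo sapiens) for metabolic stability, read by LC-MS, with NADPH named in the record, with a stated time of 60 min, tested at 1 uM, in the absence of a further agent (on this read-out higher numbers stand for a more stable compound and lower numbers for a less stable compound), compound 3 `COc1ccc(-c2c(C)nc3c(N4CC[C@@H](NS(=O)(=O)c5ccc(C)cc5)C4)cc(C)nn23)cc1OC` reads > 95% as a limit of the assay, not a number. Compound 1 `COc1ccc(-c2c(C)nc3c(N4CC[C@@H](NC(=O)C(F)(F)F)C4)cc(C)nn23)cc1OC` reads > 95% as a limit too. Compound 2 `COc1ccc(-c2c(C)nc3c(N4CC[C@@H](NS(=O)(=O)c5ccccc5)C4)cc(C)nn23)cc1OC` reads > 95% as a limit too. Compound 4 `COc1ccc(-c2c(C)nc3c(N4CC[C@@H](NS(=O)(=O)c5ccc(Cl)cc5)C4)cc(C)nn23)cc1OC` has chloro in place of methyl on an aromatic carbon, para to a large group (chloro in place of methyl on an aromatic carbon). For the measured compounds named here, three measured steps bear on this: a step that the two limits leave unreadable from compound 1 to compound 2 and a step that the two limits leave unreadable from compound 1 to compound 3 and, closest in kind, a step that the two limits leave unreadable from compound 2 to compound 3 with methyl in place of hydrogen on an aromatic carbon. The three compounds share the limit of > 95% in this assay, at which 3 of the 3 values shown sit, and so no step size can be read. Nothing beyond the usual scatter is therefore expected, in either direction. The estimated change is a number no higher from compound 3 to compound 4 (the limit leaves the size open) in this assay for now. For compound 4 the expected value is 95% with a range of 85% to 100% around it.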

Compound 4, percent of the compound remaining: > 95%
Compound 4 was reported as a limit; the forecaster's own chance of this, stated with the estimate: 60%; the middle value sits exactly at the limit.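

No new step can be read between compound 1, compound 2, compound 3 and compound 4 in this assay, as all four stop at one limit: the limit of > 95% in this assay, at which 4 of the 4 values shown sit. The compounds shown leave open how they would rank without that limit.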